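Shortening the linker from compound 1 to compound 3

This account rests on a few compounds, and the source may have more. Where it says the series, first, only, none or still open, it means among the compounds named here.

Measured so far:
compound 1 `O=S(=O)(NCCCCNCc1ccc(Br)cc1)c1cc(C(F)(F)F)cc(C(F)(F)F)c1` gives 2100 nM in a functional assay on A2780 cells (Homo sapiens) for inhibition, read by MTT assay, with a stated time of 72 h; a lower number here means a stronger inhibitor of growth, a higher number a weaker inhibitor of growth
compound 2 `COc1ccccc1CNCCCNS(=O)(=O)c1cc(C(F)(F)F)cc(C(F)(F)F)c1` gives 1500 nM in this assay

Compound 1 holds the higher of the two numbers, with compound 2 nearest: a 1.4-fold lower number from compound 1 to compound 2 (0.15 log units; within the scatter). Compound 3 `O=S(=O)(NCCCNCc1ccc(Br)cc1)c1cc(C(F)(F)F)cc(C(F)(F)F)c1` differs from compound 1 as follows: (4-bromobenzyl)amino in place of ((4-bromobenzyl)amino)methyl on a saturated chain carbon, three bonds along the chain from a sulfonamide nitrogen. Among the compounds with values here, the only measured step that bears on this change is the one from compound 1 to compound 2, which pairs a shortening of the chain with a change of the benzyl group, and that step stayed within the scatter. Within the data shown here, no measured pair separates the two parts of that step, so nothing in the data points to a shift in this assay beyond the scatter in either direction; the step of a 1.2-fold lower number from compound 1 to compound 3 (0.07 log units; within the scatter) is expected to be small. Compound 3 is therefore estimated at 1800 nM, with a range from 800 nM to 4500 nM.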

Compound 3, concentration for 50% growth inhibition: 2600 nM
Estimate against measurement, compound 3: 1.4-fold (0.16 log units) below, within the range that was stated.
By their numbers in this assay, from the lowest: compounds 2, 1 and 3 (each within the scatter of the next).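

With the 4-bromobenzyl group held fixed, the chain change alone reads in this assay as a 1.2-fold higher number from compound 1 to compound 3 (0.09 log units; within the scatter) and so stays within the scatter at this position. With the shorter chain held fixed, the change on the benzyl group alone reads as a 1.7-fold higher number from compound 2 to compound 3 (0.24 log units; within the scatter) and also stays within the scatter, so the two parts of the earlier mixed step can now be read separately, and neither part shifts growth inhibition beyond the scatter. No supporting measurement is available to explain these results.

As far as these compounds go, whether a longer chain or an amide in place of the amine would move the number beyond the scatter remains open. Also open, from the compounds shown here alone, is whether nitrile groups in place of the two trifluoromethyl groups on the shared core would do so.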